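The source may hold more compounds than are shown below. What is called first, only, known or untested is meant among the compounds shown, and "the series" means these compounds.

Compound 1 `O=c1[nH]cnc2c1c(-c1ccoc1)cn2[C@@H]1O[C@H](CO)[C@@H](O)[C@H]1O`. In a functional assay on A549 cells (Homo sapiens), read by MTT assay, with a stated time of 72 h (a higher number here means a weaker inhibitor, a lower number a stronger inhibitor), compound 1 gives > 20000 nM, a limit of the assay.
Compound 2 `Nc1nc2c(c(-c3ccoc3)cn2[C@@H]2O[C@H](CO)[C@@H](O)[C@H]2O)c(=O)[nH]1`. In this assay compound 2 gives > 20000 nM, again a limit.
Compound 3 `Cc1nc(N)c2c(-c3cc4ccccc4o3)cn([C@@H]3O[C@H](CO)[C@@H](O)[C@H]3O)c2n1`. In this assay compound 3 gives > 20000 nM, also a limit.

Compound 1 stands at the limit of this assay, as do the other two measured compounds: the limit of > 20000 nM in this assay, at which 3 of the 3 values shown sit. No value in the series is a number, so no measured step can be read. Among the measured compounds shown here, the single step between compounds that differ in one place, a step that the two limits leave unreadable from compound 1 to compound 2, is unreadable for that reason.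

Compound 4 `O=c1[nH]cnc2c1c(-c1ccccc1)cn2[C@@H]1O[C@H](CO)[C@@H](O)[C@H]1O` differs from compound 1 by phenyl in place of furan-3-yl on an aromatic carbon. For the measured compounds named here, no measured step concerns this change, and the step from compound 1 to compound 2, a step that the two limits leave unreadable from compound 1 to compound 2, gives no size to set against it. With every measured compound sitting at the limit, the step that the limit leaves unreadable from compound 1 to compound 4 is expected to leave compound 4 in the same region, with a result that is most likely again a limit. For compound 4 the estimate in this assay is 25000 nM, in the range 8000 nM to 80000 nM.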

Compound 4, half-maximal inhibitory concentration: > 100000 nM
Compound 4: a limit, no number; the forecaster's own chance of this, stated with the estimate: 75%; middle value at least 4.0-fold (0.60 log units) away from the limit.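

In this assay compound 4 gives > 100000 nM, a limit and not a number. With compound 1 also at a limit, the step between these two compounds cannot be read. The compounds shown leave open how phenyl and furan-3-yl compare, and whether any compound in the series gives a numerical value in this assay.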